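This account rests on a few compounds, and the source may have more. Where it says the series, first, only, none or still open, it means among the compounds named here.

Measured so far:
- compound 1 `O=C(Nc1cccc(-n2cc(-c3ccncc3)c(-c3cc(O)cc(Cl)c3)n2)c1)Nc1ccc(Cl)c(Cl)c1`, 56%
- compound 2 `COc1cc(Cl)cc(-c2nn(-c3cccc(NC(=O)Nc4cc(C(F)(F)F)cc(C(F)(F)F)c4)c3)cc2-c2ccncc2)c1`, 40%

In a functional assay on SK-MEL-2 cells (Homo sapiens) for inhibition, read by sulforhodamine B assay, with a stated time of 48 h, tested at 1 uM (a higher number here means a weaker effect of the compound at the concentration tested, a lower number a stronger effect), compound 1 gives the highest of the two numbers; compound 2 sits a gap below it that lies beyond the usual scatter, so compound 1 is the weaker of the two at this concentration.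

Compound 3 `COc1cc(Cl)cc(-c2nn(-c3cccc(NC(=O)Nc4ccc(Cl)c(Cl)c4)c3)cc2-c2ccncc2)c1` has not been measured yet. It keeps the shared core of compound 1 and changes one place: methyl in place of hydrogen on an oxygen on an aromatic ring, that is, hydroxy to methoxy. For the measured compounds named here, no single step of this kind has been measured here, so its size is unknown. A modest shift is expected, if any, likely downward but possibly not beyond the scatter. For compound 3 in this assay the expected value is 50%, with a range from 32% to 68%, meaning an estimated step of a number 6 percentage points lower from compound 1 to compound 3 (within the scatter).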

Compound 3, a percentage reported as activity, at one concentration (the size of the read-out at that concentration, not a potency): 80%
Compound 3: middle estimate off by 30 percentage points, on the low side, and the stated range ends below it.
By their numbers in this assay, from the lowest: compound 2; then compound 1; then compound 3.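

In this assay, putting a methyl on the oxygen of the 3-chloro-5-hydroxyphenyl group gives a number 24 percentage points higher from compound 1 to compound 3 (beyond the scatter) and so a weaker effect at the concentration tested. For the compounds shown here, this is the first single change that can be read here, and it shows that the effect depends on what this oxygen carries, with the free hydroxy going with the stronger effect. Nothing given here accounts for this step. Still open, as far as these compounds go, is how an ethyl chain on that oxygen, or an amine in place of the hydroxy, would compare.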